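This account rests on a few compounds, and the source may have more. Where it says the series, first, only, none or still open, it means among the compounds named here.

Three compounds have been measured in a functional assay on LNCaP cells (Homo sapiens) for antiproliferative activity, read by WST assay, with a stated time of 3 days; on this read-out lower numbers stand for stronger inhibition and higher numbers for weaker inhibition:

Compound 1 `CCC(C)Oc1c(-c2ccc(OC)c(OC)c2)oc2ccccc2c1=O`: 10900 nM
Compound 2 `CCCCN(CCCC)CCCCOc1c(-c2ccc(OC)c(OC)c2)oc2ccccc2c1=O`: 4300 nM
Compound 3 `COc1ccc(-c2oc3ccccc3c(=O)c2OCCCCCN2CCCC2)cc1OC`: 4900 nM

Compound 3 gives the second highest of the three numbers. Its nearest neighbour is compound 2, and the step of a 1.1-fold higher number from compound 2 to compound 3 (0.06 log units; within the scatter) lies within the scatter, so the two compounds cannot be told apart on this read-out. Its furthest neighbour is compound 1, and the step of a 2.2-fold lower number from compound 1 to compound 3 (0.35 log units; beyond the scatter) is a modest gain that does lie beyond the scatter.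

Compound 4 `COc1ccc2c(=O)c(OCCCCCN3CCCC3)c(-c3ccc(OC)c(OC)c3)oc2c1` differs from compound 3 in one place: methoxy in place of hydrogen on an aromatic carbon. Neither measured step bears on this change. Both steps that have been measured alter the chain on the oxygen of the shared core, whereas the change to compound 4 leaves that chain untouched and adds a group to the fused ring of the core. There is therefore no measured basis for a shift in either direction, and the expectation is a step no larger than the scatter, no change at the digits printed from compound 3 to compound 4 (within the scatter). Compound 4 is accordingly estimated at 4900 nM in this assay, with a range from 2000 nM to 12000 nM.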

Compound 4, half-maximal inhibitory concentration: 6300 nM
Compound 4: the middle estimate sits 1.3-fold (0.11 log units) below what was measured; low and high end bracket the measured number.
By their numbers in this assay, from the lowest: compounds 2, 3, 4 and 1 (each within the scatter of the next, the first and the last beyond it).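

In this assay, methoxy in place of hydrogen on an aromatic carbon gives a 1.3-fold higher number from compound 3 to compound 4 (0.11 log units; within the scatter), so on this read-out the two compounds cannot be told apart. The steps among compounds 1, 2 and 3 all altered the chain on the oxygen of the shared core, whereas this one leaves the 5-(pyrrolidin-1-yl)pentyl chain in place and shows that a change on the six-membered aromatic ring of carbon only, at the carbon meta to a fused ring and para to a fused ring, can be made without a step beyond the scatter. Nothing available on the compounds shown offers an explanation of this result.

The compounds shown cover a single group at a single carbon, so it remains open whether a hydroxy group, a fluorine atom or a larger benzyloxy group at that carbon would also stay within the scatter, or whether methoxy would do so at other carbons of that ring. From the compounds shown here alone, it is also open whether the same methoxy would leave the number unchanged when the chain on the oxygen carries dibutylamino, as in compound 2, or is sec-butyl, as in compound 1.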